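A few compounds are considered here, and "the series" means these few. Any claim that something is new, unique, unknown or untested is made for them only; others in the source may bear on it.

Measured so far in a functional assay on Venous blood for antagonist activity at C-X-C chemokine receptor type 3 (Homo sapiens), read by flow cytometry, with a stated time of 30 min, in the presence of a further agent that is not named here; a lower number here means a stronger inhibitor, a higher number a weaker inhibitor:
compound 1 `C[C@@H]1CN(c2sc(C(F)(F)F)nc2-c2nc3cc(Cl)ccc3[nH]2)CCN1C(=O)Cn1cnc2cccnc21`: 38.5 nM
compound 2 `C[C@@H]1CN(c2sc(C(F)(F)F)nc2-c2nc3ccccc3[nH]2)CCN1C(=O)Cn1cnc2cccnc21`: 70 nM

Compound 2 stands highest of the two numbers in this assay; compound 1 is nearest, and the step of a 1.8-fold higher number from compound 1 to compound 2 (0.26 log units; within the scatter) lies within the scatter. Compound 3 `C[C@@H]1CN(c2sc(C(F)(F)F)nc2-c2nc3ccc(CO)cc3[nH]2)CCN1C(=O)Cn1cnc2cccnc21` differs from compound 2 by hydroxymethyl in place of hydrogen on an aromatic carbon. Within the data shown here, no measured step exchanges hydrogen for hydroxymethyl; the only step that bears on substitution of this ring, a 1.8-fold higher number from compound 1 to compound 2 (0.26 log units; within the scatter), was small. The step of no change at the digits printed from compound 2 to compound 3 (within the scatter) is therefore expected to stay within the scatter. Compound 3 is estimated at 70 nM, with a range from 30 nM to 170 nM.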

Compound 3, half-maximal inhibitory concentration: 92.4 nM
The estimate for compound 3 lay 1.3-fold (0.12 log units) below the measured number; the measured number falls inside the stated range.
By their numbers in this assay, from the lowest: compounds 1, 2 and 3 (each within the scatter of the next, the first and the last beyond it).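

In this assay, hydroxymethyl on this six-membered aromatic ring gives a step that stays within the scatter: a 1.3-fold higher number from compound 2 to compound 3 (0.12 log units; within the scatter). Among these compounds, the exchange of the 5-chloro for the 6-(hydroxymethyl) group gives the first step beyond the scatter, a 2.4-fold higher number from compound 1 to compound 3 (0.38 log units; beyond the scatter), although compound 2, carrying hydrogen, lies within the scatter of both. No measurement on hand offers an explanation for either step.

Open, going by these compounds, is whether methoxymethyl, an amine or a carboxylic acid on this carbon would move the number beyond the scatter from compound 2.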